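A few compounds are considered here, and "the series" means these few. Any claim that something is new, unique, unknown or untested is made for them only; others in the source may bear on it.

Measured compounds in a functional assay on MIA PaCa-2 cells (Homo sapiens) for inhibition, read by MTT assay, with a stated time of 48 h, tested at 10 uM; a lower number here means less inhibition of growth, a higher number more inhibition of growth at the concentration tested:

- compound 1, `O=C(/C=C/c1ccc(OCc2cn(Cc3ccccc3Br)nn2)cc1)c1ccc(Br)cc1`: 43%
- compound 2, `COc1ccc(C(=O)/C=C/c2ccc(OCc3cn(Cc4ccccc4Br)nn3)cc2)cc1`: 50%
- compound 3, `O=C(/C=C/c1ccc(OCc2cn(Cc3ccccc3Br)nn2)cc1)c1ccc([N+](=O)[O-])cc1`: 34%

Among these three, compound 3 gives the lowest number. Its distance from compound 1 is small: a number 9 percentage points lower from compound 1 to compound 3 (within the scatter). Its distance from compound 2 is larger: a number 16 percentage points lower from compound 2 to compound 3 (beyond the scatter). Both of those steps, and the step of a number 7 percentage points higher from compound 1 to compound 2 (within the scatter), exchange only the bromo, methoxy or nitro group on an aromatic carbon; the rest of the shared core is untouched.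

Compound 4, `O=C(/C=C/c1ccc(OCc2cn(Cc3ccc(F)cc3)nn2)cc1)c1ccc([N+](=O)[O-])cc1`, takes a different route. It keeps the nitro group of compound 3 and changes the other end of the molecule: 4-fluorophenyl in place of 2-bromophenyl on a saturated chain carbon bound to an aromatic nitrogen. Among the compounds with values here, none of the measured steps touches this part of the structure, so there is no measured step that bears directly on the change. With nothing in the data pointing either way, the reasonable expectation is a step that stays within the usual scatter, neither clearly up nor clearly down. On that basis the expected step is a number 2 percentage points higher from compound 3 to compound 4 (within the scatter). Compound 4 is therefore estimated at 36% in this assay, with a plausible range from 18% to 54%.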

Compound 4, percent growth inhibition at one concentration: 44%
Estimate against measurement, compound 4: 8 percentage points below; the measured number falls inside the stated range.
By their numbers in this assay, from the lowest: compounds 3, 1, 4 and 2 (each within the scatter of the next, the first and the last beyond it).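

Within the data shown here, until now, every measured step had changed only the group on the aromatic carbon at the other end of the molecule, so this is the first reading on the 2-bromophenyl end. In this assay, placing 4-fluorophenyl in place of 2-bromophenyl on a saturated chain carbon bound to an aromatic nitrogen gives a number 10 percentage points higher from compound 3 to compound 4 (within the scatter), which shows that this end can be exchanged, at least with the nitro group present, without a step beyond the scatter. No measurement shown here accounts for the size of this step.

From the compounds shown here alone, this single exchange alters both the halogen and where it sits on the ring, so the two changes cannot be separated, and it is unknown whether the 4-fluorophenyl group would give a similar step alongside the methoxy or bromo group at the other end. Also unknown is how the number would respond to a plain phenyl with no halogen, to an amine on that ring, or to a longer chain in place of the single saturated carbon that links the ring to the aromatic nitrogen.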